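Swapping Methoxy for Fluoro on a Shared Core

This account rests on a few compounds, and the source may have more. Where it says the series, first, only, none or still open, it means among the compounds named here.

Compound 1 `COc1ccc2[nH]cc(-c3nc(C(=O)Nc4cc(OC)c(OC)c(OC)c4)cs3)c2c1`: 29600 nM
Compound 2 `O=C(Nc1ccccc1)c1csc(-c2c[nH]c3ccccc23)n1`: > 100000 nM
Compound 3 `COc1ccc(NC(=O)c2csc(-c3c[nH]c4ccc(F)cc34)n2)cc1`: 3410 nM

In a functional assay on HeLa cells (Homo sapiens) for cytotoxicity, read by MTT assay, with a stated time of 48 h, in the absence of a further agent (a higher number here means a weaker inhibitor, a lower number a stronger inhibitor), compound 1 gives the highest of the two numbers shown. Its nearest neighbour, compound 3, gives 3410 nM, a lower number beyond the usual scatter, although the two compounds differ in more than one place. Compound 2 reaches only a limit of the assay, > 100000 nM, which is not a number. Compound 4 `COc1cc(NC(=O)c2csc(-c3c[nH]c4ccc(F)cc34)n2)cc(OC)c1OC` carries fluoro in place of methoxy on an aromatic carbon. For the measured compounds named here, no pair of measured compounds isolates this change, so the step cannot be read off. A modest step downward is expected, a 3.0-fold lower number from compound 1 to compound 4 (0.47 log units; beyond the scatter). Compound 4 is therefore expected to give about 10000 nM, within a range of 2000 nM to 40000 nM.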

Compound 4, half-maximal inhibitory concentration: > 100000 nM
Compound 4 ended at the assay's limit; the forecaster's own chance of this, stated with the estimate: 5%; at least 10-fold (1.00 log units) between middle value and limit.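

Fluoro in place of methoxy on this aromatic carbon gives the first direct reading at this position: in this assay the change brings an at least 3.3-fold higher number from compound 1 to compound 4 (0.52 log units; beyond the scatter), so methoxy here goes with the lower number. Compound 4 gives > 100000 nM, which is a limit of the assay and not a number. The full size of the step therefore stays unknown, and this reading is bounded by that limit: the limit of > 100000 nM in this assay, at which 2 of the 4 values shown sit.

The compounds shown leave open whether a hydroxyl or an amine on this carbon would match methoxy, and whether a longer ethoxy chain would give a lower number still.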